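Swapping Vinyl for Hydroxymethyl on the Side Chain

The source may report more compounds than this note shows. Statements on the series, on what has been measured and on what is new or still open speak of the compounds shown alone.

Compound 1 `Cn1ncc(Cl)c1-c1cc(C(=O)N[C@@H]2CN[C@H](CCn3cncn3)C[C@H]2c2ccc(Cl)c(Cl)c2)oc1Cl`: 560 nM
Compound 2 `Cn1ncc(Cl)c1-c1cc(C(=O)N[C@@H]2CN[C@H](CC(=O)O)C[C@H]2c2ccc(Cl)c(Cl)c2)oc1Cl`: 4020 nM
Compound 3 `C=CC[C@@H]1C[C@@H](c2ccc(Cl)c(Cl)c2)[C@H](NC(=O)c2cc(-c3c(Cl)cnn3C)c(Cl)o2)CN1`: 780 nM

Three compounds share one core and differ only in the group on a saturated chain carbon bound to a saturated ring carbon. In a functional assay on HCT-116 cells (Homo sapiens) for antiproliferative activity, read by sulforhodamine B assay, with a stated time of 72 h (on this read-out lower numbers stand for stronger inhibition and higher numbers for weaker inhibition), compound 1 gives 560 nM, compound 2 gives 4020 nM and compound 3 gives 780 nM. Compound 3 thus holds the second highest of the three numbers: the step of a 1.4-fold higher number from compound 1 to compound 3 (0.14 log units; within the scatter) lies within the scatter, so compounds 1 and 3 cannot be told apart, whereas the step of a 5.2-fold lower number from compound 2 to compound 3 (0.71 log units; beyond the scatter) sets compound 3 clearly below the carboxy compound 2.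

Compound 4 `Cn1ncc(Cl)c1-c1cc(C(=O)N[C@@H]2CN[C@H](CCO)C[C@H]2c2ccc(Cl)c(Cl)c2)oc1Cl` is the next step from compound 3: hydroxymethyl in place of vinyl on a saturated chain carbon bound to a saturated ring carbon. Both measured steps that end at compound 3 bear on this change. Replacing the (1H-1,2,4-triazol-1-yl)methyl group by vinyl cost nothing beyond the scatter, while replacing carboxy by vinyl brought a modest gain. A hydroxymethyl group is neither the charged carboxy nor the uncharged triazole, so the step of a 1.2-fold higher number from compound 3 to compound 4 (0.06 log units; within the scatter) is expected to be a small rise in the number, possibly within the scatter. Compound 4 is therefore estimated at 900 nM, with a range from 400 nM to 2500 nM.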

Compound 4, half-maximal inhibitory concentration: 340 nM
Estimate against measurement, compound 4: 2.6-fold (0.42 log units) above, and the stated range ends above it.
By their numbers in this assay, from the lowest: compounds 4, 1 and 3 (each within the scatter of the next, the first and the last beyond it); then compound 2.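

In this assay, for the compounds shown here, the change from vinyl to hydroxymethyl gives a 2.3-fold lower number from compound 3 to compound 4 (0.36 log units; beyond the scatter) and is the first step at this position without carboxy on either side that lies beyond the scatter, with the entering group bringing a hydrogen-bond donor and acceptor that vinyl lacks. With a 12-fold lower number from compound 2 to compound 4 (1.07 log units; beyond the scatter) comes the largest step seen here, and it shows that oxygen on this side chain does not by itself go with a high number: among the compounds shown, only the carboxy compound 2 stands apart from all the others. With a 1.6-fold lower number from compound 1 to compound 4 (0.22 log units; within the scatter) the hydroxy and 1H-1,2,4-triazol-1-yl ends of the chain cannot be told apart, so two quite different groups give numbers within the scatter of each other, and vinyl is separated from hydroxymethyl but not from the triazole.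

Nothing given here ties these differences to a measured property. Going by these compounds, it remains open whether an amine, a methyl ether or a longer chain ending in hydroxy would keep the number of compound 4 or move it, and whether a primary amide would share the high number of the carboxy compound 2.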